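Bromo for Fluoro on the 4-Fluorophenyl of Compound 2

The source may report more compounds than this note shows. Statements on the series, on what has been measured and on what is new or still open speak of the compounds shown alone.

Of the compounds shown here, two of a shared core have been measured in a functional assay on DU-145 cells (Homo sapiens) for cytotoxicity, read by trypan blue exclusion, with a stated time of 96 h; on this read-out higher numbers stand for weaker inhibition and lower numbers for stronger inhibition. Compound 1 `COC(=O)C(C)(C)Nc1cc(NS(=O)(=O)/C=C/c2c(OC)cc(OC)cc2OC)ccc1OC` gives 200 nM in this assay. Compound 2 `COC(=O)C(Nc1cc(NS(=O)(=O)/C=C/c2c(OC)cc(OC)cc2OC)ccc1OC)c1ccc(F)cc1` gives 2500 nM. Among the compounds with values here, the single measured step, a 13-fold higher number from compound 1 to compound 2 (1.10 log units; beyond the scatter), puts (4-fluorophenyl)(methoxycarbonyl)methyl in place of 1-(methoxycarbonyl)-1-methylethyl on a nitrogen on an aromatic ring. Compound 2 therefore stands at the highest of the two numbers, with compound 1 a long way lower.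

Compound 3 `COC(=O)C(Nc1cc(NS(=O)(=O)/C=C/c2c(OC)cc(OC)cc2OC)ccc1OC)c1ccc(Br)cc1` differs from compound 2 in one place: bromo in place of fluoro on an aromatic carbon. The change is an exchange of one halogen for another, 4-fluorophenyl becoming 4-bromophenyl. Within the data shown here, no measured step bears on this position: the one known step concerns the group on the nitrogen, and its size says nothing about an exchange of one halogen for another on the 4-fluorophenyl. With nothing to lean on, the expected step of no change at the digits printed from compound 2 to compound 3 (within the scatter) is taken to lie within the scatter, in no set direction. Compound 3 is accordingly estimated at 2500 nM, with a range from 800 nM to 8000 nM.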

Compound 3, half-maximal inhibitory concentration: 7500 nM
Beside the measured number, compound 3's estimate is 3.0-fold (0.48 log units) below it; low and high end bracket the measured number.
By their numbers in this assay, from the lowest: compound 1; then compound 2; then compound 3.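

In this assay, the halogen on this ring is not a silent exchange: bromo in place of fluoro on an aromatic carbon gives a 3.0-fold higher number from compound 2 to compound 3 (0.48 log units; beyond the scatter), a modest step beyond the scatter, and it runs towards weaker inhibition. The change also adds to the cost of the group on the nitrogen, since putting (4-bromophenyl)(methoxycarbonyl)methyl in place of 1-(methoxycarbonyl)-1-methylethyl gives a 38-fold higher number from compound 1 to compound 3 (1.57 log units; beyond the scatter), a large step that exceeds the one seen with the fluoro counterpart. Nothing at hand accounts for why bromo gives the higher number here.

The compounds shown cover only fluoro and bromo at this place, so it remains open whether chloro, a plain hydrogen, a methoxy or an amine would fall on the same trend or break it. They also leave open whether the exchange of fluoro for bromo would have a step of similar size and direction with another group on the nitrogen, such as a longer chain or a carboxylic acid in place of the methyl ester.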